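This account rests on a few compounds, and the source may have more. Where it says the series, first, only, none or still open, it means among the compounds named here.

Measured so far in a functional assay on KB cells (Homo sapiens) for cytotoxicity, read by MTT assay, with a stated time of 72 h; on this read-out lower numbers stand for an effect already at smaller amounts and higher numbers for an effect only at larger amounts of compound:
compound 1 `O=C1/C(=C\c2cccc(Oc3ccccc3)c2)c2ccccc2N1c1c(Cl)cccc1Cl`: 5 ug/mL
compound 2 `O=C1/C(=C\c2ccccc2Cl)c2ccccc2N1c1c(Cl)cccc1Cl`: 5 ug/mL
compound 3 `COc1ccc(/C=C2\C(=O)N(c3c(Cl)cccc3Cl)c3ccccc32)cc1OC`: 10 ug/mL

The three compounds share one core and differ only in the aryl group on the exocyclic double bond. In this assay compound 2 gives 5 ug/mL, level with compound 1 at the digits shown, and the gap to compound 3 lies within the scatter, so the three numbers are not separated here.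

Compound 4 `O=C1/C(=C\c2c(Cl)cccc2Cl)c2ccccc2N1c1c(Cl)cccc1Cl` is not yet measured. It differs from compound 2 by chloro in place of hydrogen on an aromatic carbon. For the measured compounds named here, no measured pair shows a step of this kind, so the expectation rests on the narrow spread of the three numbers alone: no step beyond the scatter is expected, and the step from no change at the digits printed from compound 2 to compound 4 (within the scatter) is estimated as flat. Compound 4 is expected at 5 ug/mL, with a range of 2.5 ug/mL to 12 ug/mL.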

Compound 4, concentration for half-maximal effect: 50 ug/mL
Beside the measured number, compound 4's estimate is 10-fold (1.00 log units) below it; measured number above the stated range.
By their numbers in this assay, from the lowest: compounds 1, 2 and 3 (each within the scatter of the next); then compound 4.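

The change from 2-chlorophenyl to 2,6-dichlorophenyl gives a 10-fold higher number from compound 2 to compound 4 (1.00 log units; beyond the scatter) in this assay, a step beyond the scatter from a single added chloro. For the compounds shown here, the earlier compounds, with different aryl groups on the exocyclic double bond, stayed within the scatter of one another, so this aromatic carbon is the first place where a change moves the number beyond it. Nothing measured here accounts for the step.

On these data alone, whether the step belongs to chloro alone stays open, since this rests on one pair. A fluoro, methyl or methoxy group on the same aromatic carbon would test whether other groups there give a similar step.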